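The compounds below may be only part of what the source reports. "The series", "measured", "known", "first", "only" and "open" are said of these compounds alone.

Compound 1 (`Cc1c(C(=O)NCc2cccc(O)c2)cnn1-c1ccc(Cl)cc1`) is known only through a limit. In a functional assay on cells for antagonist activity at C-C chemokine receptor type 1 (Homo sapiens), read by FLIPR and calcium flux (a higher number here means a weaker inhibitor, a lower number a stronger inhibitor), compound 1 gives > 3000 nM, which is a limit of the assay rather than a number. Among the compounds with values here, its single neighbour, compound 2 (`Cc1c(C(=O)NCc2cccc(C(N)=O)c2)cnn1-c1ccc(Cl)cc1`), is in the same position: in this assay compound 2 gives > 3000 nM, again a limit. Within the data shown here, the step that the two limits leave unreadable from compound 1 to compound 2 is therefore not readable in size, and the only thing the two values share is the limit of > 3000 nM in this assay, at which 2 of the 2 values shown sit.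

Compound 3 (`Cc1c(C(=O)NCc2ccncc2)cnn1-c1ccc(Cl)cc1`) differs from compound 1 by pyridin-4-yl in place of 3-hydroxyphenyl on a saturated chain carbon bound to an amide-type nitrogen. Among the measured compounds shown here, no measured step bears directly on this exchange: the one step recorded, from compound 1 to compound 2, cannot be read because both ends sit at the limit. With nothing to suggest a change beyond the scatter, the expectation for compound 3 is that it stays at or near the same limit in this assay. The expected step is a step that the limit leaves unreadable from compound 1 to compound 3. Compound 3 is thus estimated at 6000 nM, with a range from 1500 nM to 30000 nM.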

Compound 3, half-maximal inhibitory concentration: > 3000 nM
Compound 3: no number, only a limit (the forecaster's own chance of this, stated with the estimate: 70%); the middle value does not contradict the limit.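

In this assay compound 3, like compound 1, stands at a limit and not at a number, and no new step can be read from the comparison of compound 1 with compound 3. The compounds shown leave open how strongly compound 1, compound 2 or compound 3 acts at this receptor, and whether their exchanges alter it at all.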